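The compounds below may be only part of what the source reports. "The series", "measured", "known", "first", "only" and "open" are said of these compounds alone.

In a functional assay on PC-3 cells (Homo sapiens) for antiproliferative activity, read by MTT assay, with a stated time of 24 h (a higher number here means a weaker inhibitor, a lower number a stronger inhibitor), compound 1 `CCn1c(C(=O)N[C@H](CO)C(C)C)ccc1C(CC)(CC)c1ccc(OCS(=O)(=O)c2ccccc2)c(C)c1` gives 7300 nM, compound 2 `CCn1c(C(=O)N[C@@H](CO)C(C)C)ccc1C(CC)(CC)c1ccc(OCS(=O)(=O)c2ccccc2)c(C)c1` gives 10600 nM and compound 3 `CCn1c(C(=O)N[C@H](CO)CCO)ccc1C(CC)(CC)c1ccc(OCS(=O)(=O)c2ccccc2)c(C)c1` gives 12100 nM. Compound 3 therefore stands level with the other two, with a 1.7-fold higher number from compound 1 to compound 3 (0.22 log units; within the scatter) and a 1.1-fold higher number from compound 2 to compound 3 (0.06 log units; within the scatter). These two steps bear most directly on what follows, since each exchanges the group on the amide-type nitrogen. Among the measured compounds shown here, the remaining step is a 1.5-fold higher number from compound 1 to compound 2 (0.16 log units; within the scatter), and the only evidence on it is the fact that compounds 1 and 2 differ only in the configuration as drawn.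

The next structure is compound 4 `CCn1c(C(=O)N[C@H](C(=O)O)C(C)C)ccc1C(CC)(CC)c1ccc(OCS(=O)(=O)c2ccccc2)c(C)c1`. The change is 1-carboxy-2-methylpropyl in place of 3-hydroxy-1-(hydroxymethyl)propyl on an amide-type nitrogen, which places 1-carboxy-2-methylpropyl in place of 3-hydroxy-1-(hydroxymethyl)propyl on an amide-type nitrogen. For the measured compounds named here, none of the measured compounds carries a carboxy group, so the data cannot show what this group does on its own.

Going by the values given here, the only guide is the size of the earlier exchanges at this nitrogen, and a 1.1-fold higher number from compound 2 to compound 3 (0.06 log units; within the scatter) is the smallest of them. On that basis, no shift beyond the scatter is expected in this assay, and the expected change is a 1.2-fold higher number from compound 3 to compound 4 (0.06 log units; within the scatter). Compound 4 is estimated at 14000 nM in this assay. The expected range for compound 4 is kept wide, running from 5000 nM to 40000 nM.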

Compound 4, half-maximal inhibitory concentration: 3650 nM
The estimate for compound 4 lay 3.8-fold (0.58 log units) above the measured number; measured number below the stated range.
By their numbers in this assay, from the lowest: compounds 4, 1, 2 and 3 (each within the scatter of the next, the first and the last beyond it).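

In this assay the group on the amide-type nitrogen now gives steps beyond the scatter, which no exchange among compounds 1, 2 and 3 did: 1-carboxy-2-methylpropyl sets compound 4 apart from the 3-hydroxy-1-(hydroxymethyl)propyl group of compound 3 (a 3.3-fold lower number from compound 3 to compound 4 (0.52 log units; beyond the scatter); modest) and from the 1-(hydroxymethyl)-2-methylpropyl group of compound 2 (a 2.9-fold lower number from compound 2 to compound 4 (0.46 log units; beyond the scatter); modest). The narrowest exchange, carboxy in place of hydroxymethyl on the saturated chain carbon, stays within the scatter (a 2.0-fold lower number from compound 1 to compound 4 (0.30 log units; within the scatter)), so compound 4 stands level with compound 1, and the carboxy group is tolerated here without being shown to give a gain of its own. Nothing given here accounts for the shift.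

The compounds shown leave open whether a methyl ester, a primary amide or an amine in place of the carboxy group would stay level with compound 4. They also leave open what the opposite configuration at the carbon bearing the carboxy group would give, and whether a longer chain in place of the isopropyl group would change the number.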